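The compounds below may be only part of what the source reports. "The series", "measured", "known", "first", "only" and "open" are said of these compounds alone.

The three measured compounds share a pyrazine ester core and differ in what sits on the cinnamate ring and at its acid end. Compound 1 `COc1cc(/C=C/C(=O)O)ccc1OC(=O)c1nc(C)c(C)nc1C` carries a free acid and a methoxy group; in a functional assay on EA.hy 926 cells (Homo sapiens) for cytotoxicity, read by MTT assay, with stated times of 24 h and 12 h, tested at 12.5 uM (on this read-out lower numbers stand for a weaker effect and higher numbers for a stronger effect at the one concentration tested), compound 1 gives 38.7%. Compound 2 `CCOC(=O)/C=C/c1ccc(OC(=O)c2nc(C)c(C)nc2C)c(O)c1` carries an ethyl ester and a hydroxy group; in this assay compound 2 gives 75.7%, the highest of the three numbers, beyond the scatter above compound 1 and furthest above compound 3. Compound 3 `Cc1nc(C)c(C(=O)Oc2ccc(Cl)cc2/C=C/C(=O)O)nc1C` carries a chloro group and a free acid; in this assay compound 3 gives 6.9%, the lowest number in the set. Compound 2 is thus the reference for the next step.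

Compound 4 `CCOC(=O)/C=C/c1ccc(OC(=O)c2nc(C)c(C)nc2C)c(OC)c1` is compound 2 with one change: methyl in place of hydrogen on an oxygen on an aromatic ring. Within the data shown here, no step between two measured compounds isolates this change, since compound 1 and compound 2 differ in two places. Compound 1 does show that a compound bearing methoxy and an acid end gives a lower number than compound 2, but that comparison cannot be read as a step. In this assay the step from compound 2 to compound 4 is expected to be a modest decrease, possibly within the scatter, a number 15.7 percentage points lower from compound 2 to compound 4 (beyond the scatter). Compound 4 is estimated to give 60%, with a range from 38% to 82%.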

Compound 4, a percentage reported as activity, at one concentration (the size of the read-out at that concentration, not a potency): 52.4%
Beside the measured number, compound 4's estimate is 7.6 percentage points above it; the range from low to high includes it.
By their numbers in this assay, from the lowest: compound 3; then compound 1; then compound 4; then compound 2.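

Among these compounds, compound 4 separates the two differences between compound 1 and compound 2, which no earlier pair could do. In this assay, the change from hydroxy to methoxy on the aromatic ring, with the ethyl ester held constant, gives a number 23.3 percentage points lower from compound 2 to compound 4 (beyond the scatter), so the hydrogen on this oxygen matters to the read-out, and in this pair the hydroxy compound gives the higher number. With the methoxy group held constant, ethyl in place of hydrogen at the acid end gives a number 13.7 percentage points higher from compound 1 to compound 4 (beyond the scatter), so among these three compounds each of the two changes on its own shifts the number beyond the scatter, and the gap between compound 1 and compound 2 is not the work of one place alone; nothing given here explains either step.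

The compounds shown leave open what a longer chain on this oxygen, such as propyl or benzyl, or an amine in place of the hydroxy group would give, and what the hydroxy group gives with a carboxylic acid at the other end. Compound 3 differs from the others in more than one place, so its steps cannot be read, and the chloro group stays without a comparison.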